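Azide in place of nitrobenzoate on an antiproliferative macrocycle

The source may report more compounds than this note shows. Statements on the series, on what has been measured and on what is new or still open speak of the compounds shown alone.

Measured compounds:
compound 1 `COCOC/C1=C/C[C@](C)(CCC=C(C)C)/C=C/[C@@H](OC(=O)C=C(C)C)[C@](C)(O)/C=C/C1=O` — 2840 nM
compound 2 `CC(C)=CCC[C@]1(C)/C=C/[C@@H](OC(=O)C=C(C)C)[C@](C)(O)/C=C/C(=O)/C(COC(=O)c2ccc([N+](=O)[O-])cc2)=C\C1` — 830 nM

In a functional assay on HL-60 cells (Homo sapiens) for antiproliferative activity, read by MTT assay, with a stated time of 48 h (a lower number here means a stronger inhibitor, a higher number a weaker inhibitor), compound 2 gives 830 nM, the lowest of the two numbers, with compound 1 at 2840 nM. Within the data shown here, the only measured step is a 3.4-fold lower number from compound 1 to compound 2 (0.53 log units; beyond the scatter). Compound 3 `CC(C)=CCC[C@]1(C)/C=C/[C@@H](OC(=O)C=C(C)C)[C@](C)(O)/C=C/C(=O)/C(CN=[N+]=[N-])=C\C1` is unmeasured; it differs from compound 2 by azido in place of ((4-nitrophenyl)carbonyl)oxy on a saturated chain carbon bound to a double-bonded ring carbon. Among the measured compounds shown here, no measured step shows an azido group, so the size of the change is uncertain; the one step seen touched the same oxygen-bearing carbon and was modest. Compound 3 is therefore expected to lie near or somewhat above compound 2, the step of a 1.8-fold higher number from compound 2 to compound 3 (0.26 log units; within the scatter) being the estimate, giving 1500 nM with a range from 400 nM to 5000 nM.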

Compound 3, half-maximal inhibitory concentration: 910 nM
Compound 3: the middle estimate sits 1.6-fold (0.22 log units) above what was measured, within the range that was stated.
By their numbers in this assay, from the lowest: compounds 2 and 3 (each within the scatter of the next); then compound 1.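

In this assay, azido, with 3 heavy atoms and no ring, replaces the 12 heavy atoms and aromatic ring of ((4-nitrophenyl)carbonyl)oxy with a 1.1-fold higher number from compound 2 to compound 3 (0.04 log units; within the scatter), so that aromatic ester is not required at this saturated chain carbon to retain the activity of compound 2. Compared with methoxymethoxy, azido gives a 3.1-fold lower number from compound 1 to compound 3 (0.49 log units; beyond the scatter), showing that a second, very different group also separates from compound 1. No evidence is available to explain these results. From the compounds shown here alone, whether an amine or a free hydroxyl at this carbon would match compound 3 remains open.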